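The source may report more compounds than this note shows. Statements on the series, on what has been measured and on what is new or still open speak of the compounds shown alone.

The study sets four compounds on a shared core side by side in a functional assay on T47D cells (Homo sapiens) for cytotoxicity, read by CCK-8 assay; a higher number here means a weaker inhibitor, a lower number a stronger inhibitor. Compound 1 `Oc1ccc(-c2cc(-c3cccs3)cc(-c3ccccc3O)n2)cc1` bears a 2-hydroxyphenyl group, and in this assay compound 1 gives > 50000 nM, which is a limit of the assay and not a number. Compound 2 `Oc1ccc(-c2cc(-c3cccs3)cc(-c3cccc(O)c3)n2)cc1` differs from it in one place: 3-hydroxyphenyl in place of 2-hydroxyphenyl on an aromatic carbon. In this assay compound 2 gives 780 nM. That single change brought an at least 64-fold lower number from compound 1 to compound 2 (1.80 log units; beyond the scatter), and the step can only be bounded on one side because of the limit of > 50000 nM in this assay, at which 2 of the 3 values shown sit.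

Compound 3 `Oc1cccc(-c2cc(-c3ccsc3)cc(-c3ccccc3O)n2)c1` keeps the 2-hydroxyphenyl group of compound 1 on a core of its own; the difference between the two cores is not broken down here. In this assay compound 3 gives > 50000 nM, again a limit of the assay rather than a number. Compound 4 `Oc1cccc(-c2cc(-c3ccsc3)cc(-c3cccc(O)c3)n2)c1` has not yet been measured; relative to compound 3 it carries the same change that turned compound 1 into compound 2: 3-hydroxyphenyl in place of 2-hydroxyphenyl on an aromatic carbon. The surroundings of the place are not identical, since in compound 1 it is meta to a 4-hydroxyphenyl group and meta to a thiophen-2-yl group, whereas in compound 3 it is meta to a 3-hydroxyphenyl group and meta to a thiophen-3-yl group, so the two changes are the same kind of change, not the same.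

Resting on the step from compound 1 to compound 2, the step to compound 4 is expected to be an at least 33-fold lower number from compound 3 to compound 4 (1.52 log units; beyond the scatter) in this assay. Compound 4 is accordingly estimated at 1500 nM, with a plausible span from 300 nM to 20000 nM.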

Compound 4, half-maximal inhibitory concentration: 1510 nM
Compound 4: the middle estimate sits 1.0-fold (0.00 log units) below what was measured, within the range that was stated.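

In this assay, 3-hydroxyphenyl in place of 2-hydroxyphenyl brought an at least 33-fold lower number from compound 3 to compound 4 (1.51 log units; beyond the scatter), so the change that opened up activity on the core of compound 1 did the same on the core of compound 3. Across these two cores, then, the direction of the change carried over, and both steps lie beyond the scatter: the same change on two cores in this assay, an at least 64-fold lower number (1.80 log units; beyond the scatter) from compound 1 to compound 2 and an at least 33-fold lower number (1.51 log units; beyond the scatter) from compound 3 to compound 4; the limit leaves it open whether they differ

What this does not show is how large either step really is, or whether the core alters its size, because each step starts from a compound that gives only a limit, not a number: the limit of > 50000 nM in this assay, at which 2 of the 4 values shown sit.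

The two cores shown are also too few to establish a rule for the series as a whole, and the result says nothing about why the position of the hydroxyl group matters.

The compounds shown leave open whether the lower number depends on the hydroxyl group itself, since an amine, a methoxy group or a carboxylic acid at that position of the phenyl ring does not appear among them. They also leave open whether the same change would carry over to a core in which the thiophene is replaced by another group, such as a pyridine or a longer chain.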